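Replacing 4-fluorophenyl with 3,5-dimethylphenyl on the shared core

The source may report more compounds than this note shows. Statements on the series, on what has been measured and on what is new or still open speak of the compounds shown alone.

Within the data shown here, in a functional assay on KB cells (Homo sapiens) for cytotoxicity (on this read-out higher numbers stand for an effect only at larger amounts of compound and lower numbers for an effect already at smaller amounts), compound 1 (`COC1=C(C)C(=O)/C(=C(O)/C=C/c2ccc(F)cc2)C(=O)C1(C)C`) gives 3.7 ug/mL and compound 2 (`COC1=C(C)C(=O)/C(=C(O)/C=C/c2ccc(C)cc2)C(=O)C1(C)C`) gives 3.9 ug/mL, so compound 1 stands level with the only other measured compound. Compound 3 (`COC1=C(C)C(=O)/C(=C(O)/C=C/c2cc(C)cc(C)c2)C(=O)C1(C)C`) differs from compound 1 on a double-bonded chain carbon bound to a double-bonded chain carbon: 3,5-dimethylphenyl in place of 4-fluorophenyl on a double-bonded chain carbon bound to a double-bonded chain carbon. Among the measured compounds shown here, the one measured step that bears on this change, methyl in place of fluoro on an aromatic carbon, is a 1.1-fold higher number from compound 1 to compound 2 (0.02 log units; within the scatter). No step beyond the scatter is therefore expected in this assay, though a single step is thin evidence. For compound 3 the estimated value is 3.8 ug/mL, within an expected range of 1.7 ug/mL to 8 ug/mL. This estimate means a 1.0-fold higher number from compound 1 to compound 3 (0.01 log units; within the scatter).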

Compound 3, concentration for half-maximal effect: 3.1 ug/mL
Estimate against measurement, compound 3: 1.2-fold (0.09 log units) above; the measured number falls inside the stated range.
By their numbers in this assay, from the lowest: compounds 3, 1 and 2 (each within the scatter of the next).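

In this assay, putting 3,5-dimethylphenyl in place of 4-fluorophenyl on a double-bonded chain carbon bound to a double-bonded chain carbon leaves the number within the scatter (a 1.2-fold lower number from compound 1 to compound 3 (0.08 log units; within the scatter)). The same holds when it replaces 4-methylphenyl (a 1.3-fold lower number from compound 2 to compound 3 (0.10 log units; within the scatter)), so the three groups shown at this position cannot be told apart on this read-out. No measurement at hand explains these small differences.

The compounds shown leave open whether an amine or a carboxylic acid in place of the 3,5-dimethylphenyl would bring a step beyond the scatter.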